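Turning the double bond of compound 2 from E to Z

The source may hold more compounds than are shown below. What is called first, only, known or untested is meant among the compounds shown, and "the series" means these compounds.

Measured so far:
Compound 1 `O=C1NC(=O)N(Cc2ccccc2)/C1=C\c1ccccc1` gives 42% in a functional assay on A549 cells (Homo sapiens) for antiproliferative activity, read by trypan blue exclusion, with a stated time of 72 h, tested at 20 uM; a higher number here means more inhibition at the concentration tested (going by the name of the read-out), a lower number less inhibition.
Compound 2 `O=C1NC(=O)N(c2ccccc2)/C1=C/c1ccccc1` gives 18% in this assay.

Compound 2 stands lowest of the two numbers, and its nearest neighbour, compound 1, lies higher by a gap beyond the scatter. Compound 3 `O=C1NC(=O)N(c2ccccc2)/C1=C\c1ccccc1` differs from compound 2 only in configuration as drawn (the two compounds have the same atoms and bonds and differ only in configuration as drawn: 1 of 1 stereo elements differ; a double bond is drawn E in compound 2 and Z in compound 3). Among the compounds with values here, no measured pair shows this change alone, so its size is unknown; compound 1 also carries a different group on the ring nitrogen, so its higher value cannot be credited to the Z drawing. A small rise is expected, a number 8 percentage points higher from compound 2 to compound 3 (within the scatter), giving compound 3 an estimated 26% with a range from 8% to 48%.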

Compound 3, a percentage reported as inhibition, at one concentration (the size of the read-out at that concentration, not a potency): 26%
Compound 3: middle estimate and measured number agree at the digits printed; the measured number falls inside the stated range.
By their numbers in this assay, from the lowest: compounds 2 and 3 (each within the scatter of the next); then compound 1.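

The double bond alone can now be judged: going from E to Z gives a number 8 percentage points higher from compound 2 to compound 3 (within the scatter) in this assay, so the drawn configuration has no effect here that stands clear of the scatter. This reading rests on a single fact: the fact that compounds 2 and 3 differ only in the configuration as drawn With the double bond drawn Z in both compounds, the group on the ring nitrogen can also be compared, and phenyl in place of benzyl gives a number 16 percentage points lower from compound 1 to compound 3 (beyond the scatter). Still open, on these data alone, is how a longer chain or an amine on that nitrogen would fare, and whether the configuration counts with benzyl there.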